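The source may report more compounds than this note shows. Statements on the series, on what has been measured and on what is new or still open speak of the compounds shown alone.

Measured compounds:
- Compound 1, `O=C1CCC(=O)N1C[C@H]1CN(c2ccc(-n3cc(-c4ccccn4)cn3)c(F)c2)C(=O)O1`: 1.58
- Compound 2, `O=C1O[C@@H](Cn2ccnn2)CN1c1ccc(-n2cc(-c3ccccn3)cn2)c(F)c1`: 2

Compound 1, `O=C1CCC(=O)N1C[C@H]1CN(c2ccc(-n3cc(-c4ccccn4)cn3)c(F)c2)C(=O)O1`, and compound 2, `O=C1O[C@@H](Cn2ccnn2)CN1c1ccc(-n2cc(-c3ccccn3)cn2)c(F)c1`, share one core and differ only in the group on the saturated chain carbon bound to a saturated ring carbon. In a physicochemical assay for lipophilicity, read by HPLC, measured as octanol-water partition (on this read-out lower numbers stand for lower lipophilicity and higher numbers for higher lipophilicity), compound 1 gives 1.58, and compound 2 gives 2. Within the data shown here, the one measured step, a number 0.42 log units higher from compound 1 to compound 2 (beyond the scatter), puts compound 2 at the higher of the two numbers, with compound 1 as its only neighbour.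

Compound 3, `CNC(=O)[C@H]1CN(c2ccc(-n3cc(-c4ccccn4)cn3)c(F)c2)C(=O)O1`, follows from compound 2 by a change at a different place: methylcarbamoyl in place of (1H-1,2,3-triazol-1-yl)methyl on a saturated ring carbon. Among the measured compounds shown here, no measured pair covers this exchange, so the step of compound 1 to compound 2 is only a loose guide to how much a swap of a small group can move this read-out. Since the group that leaves is aromatic and the group that enters carries a hydrogen-bond donor and fewer heavy atoms, a downward step is expected rather than an upward one; the estimated step is a number 0.50 log units lower from compound 2 to compound 3 (beyond the scatter). For compound 3 the expected value in this assay is 1.5, within a range from 1 to 2.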

Compound 3, partition coefficient: 1.39
Beside the measured number, compound 3's estimate is 0.11 log units above it, within the range that was stated.
By their numbers in this assay, from the lowest: compounds 3 and 1 (each within the scatter of the next); then compound 2.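

In this assay, the exchange at this saturated ring carbon of a five-membered non-aromatic ring gives a number 0.61 log units lower from compound 2 to compound 3 (beyond the scatter) and shows that the read-out also moves when the whole (1H-1,2,3-triazol-1-yl)methyl group gives way to methylcarbamoyl, an open group with no ring, whereas the earlier pair had only exchanged one ring on the chain carbon for another. The same methylcarbamoyl set against the (2,5-dioxopyrrolidin-1-yl)methyl group gives a number 0.19 log units lower from compound 1 to compound 3 (within the scatter) and so leaves compound 1 and compound 3 level in this read-out even though the two groups share neither a ring nor a chain carbon, which means that among these three compounds only compound 2 stands apart from the other two. Nothing measured here accounts for either step, so the numbers record the changes without explaining them.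

What the compounds shown leave open is how a primary amine, a carboxylic acid or a longer amide chain on this same ring carbon would read against these three. They also leave open whether methylcarbamoyl would give a similar step on a different core.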